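Six-membered aromatic ring returning in place of oxadiazole

A few compounds are considered here, and "the series" means these few. Any claim that something is new, unique, unknown or untested is made for them only; others in the source may bear on it.

Compound 2 `Cc1oc(C(=O)O)cc1COc1ccc(-c2nnco2)cc1` sits at the bottom of the two values measured: in an assay on cells for displacement of a labelled ligand from prostaglandin E2 receptor EP4 subtype (Homo sapiens), read by scintillation counting (a higher number here means a weaker inhibitor, a lower number a stronger inhibitor), compound 2 gives only a limit, > 10000 nM. Compound 1 `Cc1oc(C(=O)O)cc1COc1ccc(-c2ccc(CO)cc2)cc1` gives 3000 nM in this assay; the step of an at least 3.3-fold higher number from compound 1 to compound 2 (0.52 log units; beyond the scatter) ended at the limit of > 10000 nM in this assay, at which 1 of the 2 values shown sits. Compound 3 `COc1ccc(-c2ccc(OCc3cc(C(=O)O)oc3C)cc2)nc1` differs from compound 2 by 5-methoxypyridin-2-yl in place of 1,3,4-oxadiazol-2-yl on an aromatic carbon. Among the compounds with values here, the only measured step, an at least 3.3-fold higher number from compound 1 to compound 2 (0.52 log units; beyond the scatter), went from a six-membered aromatic ring to the oxadiazole; compound 3 reverses that kind of change, so a lower number is expected, about an at least 2.5-fold lower number from compound 2 to compound 3 (0.39 log units; beyond the scatter). Compound 3 is therefore estimated at 4000 nM, in a range from 1000 nM to 15000 nM.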

Compound 3, inhibition constant: 1300 nM
For compound 3 the middle estimate is 3.1-fold (0.49 log units) above the measured one, and the stated range covers the measured number.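

On an aromatic carbon para to a large group, 5-methoxypyridin-2-yl in place of the oxadiazole gives an at least 7.6-fold lower number from compound 2 to compound 3 (0.88 log units; beyond the scatter), so a six-membered aromatic ring again gives a measurable number. It also improves on 4-(hydroxymethyl)phenyl, with a 2.3-fold lower number from compound 1 to compound 3 (0.36 log units; beyond the scatter), so the six-membered ring here need not be carbon only. The first step has no upper bound because compound 2 gives only a limit: the limit of > 10000 nM in this assay, at which 1 of the 3 values shown sits.

The compounds shown do not separate the contribution of the ring nitrogen from that of the methoxy group. As far as these compounds go, how an amine or a carboxylic acid in place of that methoxy group would read remains open.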